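Dropping the fluoro group: what compound 4 should give

A few compounds are considered here, and "the series" means these few. Any claim that something is new, unique, unknown or untested is made for them only; others in the source may bear on it.

Compound 3 `Cn1cc(C(=O)c2ccc(F)cc2)cc1/C=C/C(=O)NO` gives 84% in an assay on isolated protein for inhibition of histone deacetylase HD2 (Zea mays), tested at 30 uM; on this read-out lower numbers stand for less inhibition and higher numbers for more inhibition at the one concentration tested (going by the name of the read-out). Among the three numbers at hand, compound 3 and compound 1 stand together, well apart from compound 2. Compound 1 `Cn1cc(C(=O)c2ccc([N+](=O)[O-])cc2)cc1/C=C/C(=O)NO` carries nitro where fluoro sits in the other; in this assay compound 1 gives 78%, and the step of a number 6 percentage points higher from compound 1 to compound 3 (within the scatter) lies within the scatter. Compound 2 `Cn1cc(C(=O)c2ccccc2)cc1/C=C/C(=O)NN`, whose acyl end is not a hydroxamic acid, gives 0.2% in this assay, a number far below that of compound 3.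

Compound 4 `Cn1cc(C(=O)c2ccccc2)cc1/C=C/C(=O)NO` differs from compound 3 in one place: hydrogen in place of fluoro on an aromatic carbon. Going by the values given here, the one measured step that bears on this change is a number 6 percentage points higher from compound 1 to compound 3 (within the scatter), which shifted the read-out by less than the scatter. Among the compounds with values here, no measured compound pairs a plain phenyl with a hydroxamic acid, so the change to hydrogen is judged by that step alone. Since two different groups at this carbon gave numbers within the scatter of each other, the expectation is that the step of a number 4 percentage points lower from compound 3 to compound 4 (within the scatter) stays within the scatter as well. Compound 4 is therefore expected to give 80% in this assay, with a range from 65% to 92%.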

Compound 4, a percentage reported as inhibition, at one concentration (the size of the read-out at that concentration, not a potency): 86%
Beside the measured number, compound 4's estimate is 6 percentage points below it, and the stated range covers the measured number.
By their numbers in this assay, from the lowest: compound 2; then compounds 1, 3 and 4 (each within the scatter of the next).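

In this assay the step of a number 2 percentage points higher from compound 3 to compound 4 (within the scatter) shows that going from 4-fluorophenyl to phenyl leaves the read-out within the scatter, so that nitro, fluoro and hydrogen on this aromatic carbon have now all been compared without any two of them separating. The one direct comparison of hydrogen with nitro, the step of a number 8 percentage points higher from compound 1 to compound 4 (within the scatter) also stays within the scatter, so no substituent effect shows at this carbon among these three groups. Going by these compounds alone, compound 4 also supplies the first pair that differs in one place at the acyl end, where hydroxy in place of amino on the amide-type nitrogen gives the step of a number 85.8 percentage points higher from compound 2 to compound 4 (beyond the scatter) and thus ties the large gap to that single change, whereas every earlier comparison with compound 2 also carried a second difference on the aromatic carbon.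

The compounds shown leave open whether an amine, a methoxy group or a carboxylic acid on that same aromatic carbon would also stay within the scatter, and whether any acyl end other than these two would hold the read-out. Nothing measured here offers a reason for the flat result at the aromatic carbon or for the large step at the nitrogen.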